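A few compounds are considered here, and "the series" means these few. Any claim that something is new, unique, unknown or untested is made for them only; others in the source may bear on it.

Compound 1, `COc1cccc(CNCCCNc2ccnc3cc(Cc4cc(C)cc(C)c4)ccc23)c1O`, is the starting point. In a physicochemical assay for solubility, with a stated time of 18 h, at pH 7.4 (on this read-out higher numbers stand for higher solubility and lower numbers for lower solubility), compound 1 gives 4200 nM, level with compound 2, `COc1ccc(F)cc1CNCCCNc1ccnc2cc(Cc3cc(C)cc(C)c3)ccc12`, which in this assay gives 4200 nM. Going by the values given here, the one measured step, no change at the digits printed from compound 1 to compound 2 (within the scatter), alters a different part of the molecule from the one changed next. Compound 3, `COc1ccccc1Oc1ccc2c(NCCCNCc3cccc(OC)c3O)ccnc2c1`, differs from compound 1 by 2-methoxyphenoxy in place of 3,5-dimethylbenzyl on an aromatic carbon. Among the compounds with values here, no measured step touches this position, so the direction is open; the expected step of a 1.4-fold higher number from compound 1 to compound 3 (0.15 log units; within the scatter) is small, and compound 3 is expected to give 6000 nM, within 2000 nM to 18000 nM.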

Compound 3, solubility: 14500 nM
Compound 3: middle estimate off by 2.4-fold (0.38 log units), on the low side; the measured number falls inside the stated range.
By their numbers in this assay, from the lowest: compounds 1 and 2 (each within the scatter of the next); then compound 3.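

Going by these compounds alone, of the two positions changed so far, this aromatic carbon is the one where a swap moves the number in this assay beyond the scatter: 2-methoxyphenoxy in place of 3,5-dimethylbenzyl gives the step (a 3.5-fold higher number from compound 1 to compound 3 (0.54 log units; beyond the scatter)). Both groups have 9 heavy atoms and one six-membered aromatic ring, but the entering group has 2 oxygen atoms and 2 hydrogen-bond acceptors. No measurement here gives a reason for the step. As far as these compounds go, it remains open whether a plain phenoxy group would give the same number, and what an amine or a carboxylic acid on this carbon would give.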